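The compounds below may be only part of what the source reports. "The series", "measured", "known", "first", "only" and "open" are said of these compounds alone.

Compound 2 `O=C(O)c1cnc2c(Cl)cccc2c1`: 150 mg/kg
Compound 1 `O=C(O)c1cnc2c(F)cccc2c1O`: > 100 mg/kg

Among the compounds with values here, in a functional assay on the whole organism (strain Sprague-Dawley) for inhibition, with Rattus norvegicus as the target (on this read-out lower numbers stand for an effect already at smaller amounts and higher numbers for an effect only at larger amounts of compound), compound 2 gives 150 mg/kg, the only number among the two values shown. Compound 1 stands at a limit of the assay, > 100 mg/kg, and not at a number (the limit of > 100 mg/kg in this assay, at which 1 of the 2 values shown sits). Compound 3 `O=C(O)c1cnc2c(F)cccc2c1` differs from compound 2 by fluoro in place of chloro on an aromatic carbon. Within the data shown here, with no step between measured compounds to lean on, the exchange of one halogen for another is expected to move the dose little, if at all, beyond the scatter. Compound 3 is therefore estimated at 150 mg/kg, between 60 mg/kg and 400 mg/kg, a step of no change at the digits printed from compound 2 to compound 3 (within the scatter) that is expected to stay small.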

Compound 3, minimum effective dose: 150 mg/kg
Compound 3: the middle estimate sits on the measured number at the digits printed; the measured number falls inside the stated range.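

Fluoro in place of chloro on this aromatic carbon, ortho to a fused ring, gives no change at the digits printed from compound 2 to compound 3 (within the scatter) in this assay, so the two halogens cannot be told apart here on this read-out. Compound 1 stands at a limit and not at a number, so the step that carries hydrogen in place of hydroxy cannot be read: the limit of > 100 mg/kg in this assay, at which 1 of the 3 values shown sits.

From the compounds shown here alone, what an amine or a methoxy group on this carbon would do to the dose stays open. So does the contribution of the hydroxy group of compound 1.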